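Replacing a Naphthalene by Fluorophenyl on the Sulfonamide

A few compounds are considered here, and "the series" means these few. Any claim that something is new, unique, unknown or untested is made for them only; others in the source may bear on it.

Compound 1 `Cc1cccc(S(=O)(=O)NCc2ccc(CNC(=O)c3cccnc3)cc2)c1` gives 10 nM in an assay on MDA-MB-231 cells for displacement of a labelled ligand from C-X-C chemokine receptor type 4 (Homo sapiens), read by fluorescence and microscopy, with stated times of 10 min and 30 min; a higher number here means that more compound is needed for the effect, a lower number that less compound is needed. Compound 3 `O=C(NCc1ccc(CNS(=O)(=O)c2ccc([N+](=O)[O-])cc2)cc1)c1cccnc1` gives 100 nM, and the step of a 10-fold higher number from compound 1 to compound 3 (1.00 log units; beyond the scatter) shows that the aryl group on the sulfonyl sulfur can shift the read-out. Compound 2 `COc1ccccc1C(=O)NCc1ccc(CNS(=O)(=O)c2cccc3ccccc23)cc1` sits at a limit of the assay, > 1000 nM, the limit (the limit of > 1000 nM in this assay, at which 1 of the 3 values shown sits). Compound 4 `COc1ccccc1C(=O)NCc1ccc(CNS(=O)(=O)c2ccc(F)cc2)cc1` differs from compound 2 by 4-fluorophenyl in place of naphthalen-1-yl on a sulfonyl sulfur. Among the measured compounds shown here, no measured step covers this particular exchange, and compound 2 offers only a limit to start from, so the direction of the change is open. Compound 4 is expected to give about 500 nM, with a range from 100 nM to 3000 nM. This estimate corresponds to an expected step of an at least 2.0-fold lower number from compound 2 to compound 4 (0.30 log units; that floor lies within the scatter).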

Compound 4, effective concentration (reported as EC, without a stated level of effect): 100 nM
Compound 4: the middle estimate sits 5.0-fold (0.70 log units) above what was measured, and the stated range covers the measured number.
By their numbers in this assay, from the lowest: compound 1; then compounds 3 and 4 (each within the scatter of the next). At a limit, above all of these: compound 2.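

On the sulfonyl sulfur, exchanging the two-ring naphthalen-1-yl for the one-ring 4-fluorophenyl gives an at least 10-fold lower number from compound 2 to compound 4 (1.00 log units; beyond the scatter). Until now, a shift at this position had been seen only from compound 1 to compound 3, which carry a different group on the amide carbonyl. The size of the new step is only a floor, since compound 2 starts from a limit of the assay: the limit of > 1000 nM in this assay, at which 1 of the 4 values shown sits.

The exchange changes the number of rings and brings in fluorine together, and the compounds shown do not separate the two. Nor do they show how a plain phenyl or a 4-aminophenyl on the sulfonyl sulfur would read.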